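This account rests on a few compounds, and the source may have more. Where it says the series, first, only, none or still open, it means among the compounds named here.

Compound 2, `COc1cc(Nc2nc(C)cc(N(C)C)n2)ccc1F`, is one of three compounds whose cytotoxicity was measured in an ADME assay on Vero cells (Chlorocebus sabaeus) for cytotoxicity; a lower number here means that less compound is needed, a higher number that more compound is needed for the effect. Compound 2 gives 31600 nM. Compound 3, `COc1cc(Nc2nc(C)cc(N3CCCCC3)n2)ccc1F`, gives 15800 nM, and the step of a 2.0-fold lower number from compound 2 to compound 3 (0.30 log units; within the scatter) sits within the scatter of repeated measurements, so these two values cannot be told apart. Compound 1, `COc1cccc(Nc2nc(C)cc(N(C)C)n2)c1`, gives > 50100 nM, which is a limit of the assay rather than a number. The step of an at least 1.5-fold lower number from compound 1 to compound 2 (0.20 log units; that floor lies within the scatter) has a floor that also lies within the scatter. Compound 4, `COc1cc(Nc2nccc(N(C)C)n2)ccc1F`, differs from compound 2 by hydrogen in place of methyl on an aromatic carbon. Neither of the measured steps concerns this position, and both stayed within the scatter, so for compound 4 no shift beyond the scatter is expected in this assay. The step of no change at the digits printed from compound 2 to compound 4 (within the scatter) is therefore expected to be small. Compound 4 is estimated at 31600 nM, with a likely range from 15000 nM to 63000 nM.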

Compound 4, half-maximal effective concentration: > 50100 nM
Compound 4: no number, only a limit; the forecaster's own chance of this, stated with the estimate: 25%; at least 1.5-fold (0.20 log units) between middle value and limit.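

In this assay compound 4 gives > 50100 nM, which is a limit of the assay and not a number. This is the first reading at the position next to the ring nitrogen, and hydrogen in place of methyl there goes with an at least 1.5-fold higher number from compound 2 to compound 4 (0.20 log units; that floor lies within the scatter), so the change gives no sign of a lower number, though no shift beyond the scatter is shown either. The true size of the step cannot be read, because compound 4 stops at the limit of the assay: the limit of > 50100 nM in this assay, at which 2 of the 4 values shown sit.

The compounds shown leave open whether an ethyl group, an amine or a methoxy group at this position would move the number in either direction. They also leave open whether hydrogen here would behave the same way with piperidin-1-yl in place of dimethylamino.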